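The source may hold more compounds than are shown below. What is called first, only, known or untested is meant among the compounds shown, and "the series" means these compounds.

Measured compounds:
compound 1 `NC(=O)c1ccc(Cn2ncc3c(Nc4ccc(OC(F)(F)F)cc4)ncnc32)cc1` — > 10000 nM
compound 2 `Cc1nc(C)c(Cn2ncc3c(Nc4ccc(OC(F)(F)F)cc4)ncnc32)s1` — > 10000 nM
compound 3 `FC(F)(F)Oc1ccc(Nc2ncnc3c2cnn3CC2CCOC2)cc1` — > 10000 nM

In an ADME assay on BaF3 cells (Mus musculus) for cytotoxicity (a lower number here means that less compound is needed, a higher number that more compound is needed for the effect), compound 3 gives > 10000 nM, which is a limit of the assay and not a number. Compound 1 likewise gives > 10000 nM, a limit. Compound 2 gives > 10000 nM, again a limit. All three values therefore sit at the limit of > 10000 nM in this assay, at which 3 of the 3 values shown sit, so compound 3 cannot be placed relative to the other two beyond sharing that limit. The steps between them are accordingly unreadable: a step that the two limits leave unreadable from compound 1 to compound 2, a step that the two limits leave unreadable from compound 1 to compound 3 and a step that the two limits leave unreadable from compound 2 to compound 3.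

Compound 4 `NC(=O)Cn1ncc2c(Nc3ccc(OC(F)(F)F)cc3)ncnc21` differs from compound 3 by the change (carbamoyl in place of oxolan-3-yl on a saturated chain carbon bound to an aromatic nitrogen). Going by the values given here, none of the measured steps bears readably on this change, since all of them run between limits; the only evidence is that three distinct groups at this position all left the compound at the limit in this assay. No step beyond the usual scatter is expected in either direction.

The step from compound 3 to compound 4 is therefore estimated as a step that the limit leaves unreadable from compound 3 to compound 4. Compound 4 is expected to give about 15000 nM in this assay, within a range from 5000 nM to 50000 nM, most likely again reported only as a limit.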

Compound 4, half-maximal effective concentration: 3300 nM
The estimate for compound 4 lay 4.5-fold (0.66 log units) above the measured number; measured number below the stated range.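

In this assay, going by these compounds alone, the group on the saturated chain carbon bound to an aromatic nitrogen now proves able to shift the read-out; the earlier compounds could not show this, as the steps among them cannot be read. Carbamoyl in place of oxolan-3-yl gives an at least 3.0-fold lower number from compound 3 to compound 4 (0.48 log units; beyond the scatter), carbamoyl in place of 2,4-dimethyl-1,3-thiazol-5-yl gives an at least 3.0-fold lower number from compound 2 to compound 4 (0.48 log units; beyond the scatter), and carbamoyl in place of 4-carbamoylphenyl gives an at least 3.0-fold lower number from compound 1 to compound 4 (0.48 log units; beyond the scatter). Within the data shown here, a carbamoyl group alone is not enough, for compound 1 also carries one, within its 4-carbamoylphenyl group, and stays at the limit, leaving compound 4 the only compound with a number: the limit of > 10000 nM in this assay, at which 3 of the 4 values shown sit.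

Going by these compounds, the true size of these steps stays open, as each of them starts from a limit and not from a number. Whether a carboxylic acid, an amine or a longer chain ending in carbamoyl at this place would give a lower or a higher number than compound 4 is not settled by the compounds shown.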